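The source may report more compounds than this note shows. Statements on the series, on what has been measured and on what is new or still open speak of the compounds shown alone.

Working notes on the series, read in an ADME assay for pharmacokinetics, read by LC-MS, in phosphate buffer, with a stated time of 120 min, at pH 7.4, tested at 1 uM, in the presence of a further agent that is not named here; on this read-out lower numbers stand for a shorter-lived compound and higher numbers for a longer-lived compound. Compound 1 `C=C(CO)C(=O)Nc1ccccc1` reaches only a limit of the assay, > 8.53 h, so it stands at the limit of > 8.53 h in this assay, at which 1 of the 3 values shown sits, rather than at a number. For the measured compounds named here, compound 2 `O=C(/C=C/C(F)(F)F)Nc1ccccc1` gives 0.267 h and compound 3 `CN(C)CC/C=C/C(=O)Nc1ccccc1` gives 7.38 h, and this pair is the one measured step, a 28-fold higher number from compound 2 to compound 3 (1.44 log units; beyond the scatter). Compound 4 `C=C(C(=O)Nc1ccccc1)C(F)(F)F` differs from compound 1 by trifluoromethyl in place of hydroxymethyl on a double-bonded chain carbon bound to a carbonyl carbon. Going by the values given here, the measured step runs the other way, trifluoromethyl leaving rather than entering, and on a different chain carbon, yet it is the only guide: trifluoromethyl on the chain coincides with the lower number of that pair. A large fall from compound 1 is expected, an at least 17-fold lower number from compound 1 to compound 4 (1.23 log units; beyond the scatter). The limit on compound 1 leaves the true size of that fall open. Compound 4 is estimated at 0.5 h, within 0.1 h to 3 h.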

Compound 4, half-life: 0.25 h
Estimate against measurement, compound 4: 2.0-fold (0.30 log units) above; measured number inside the range.
By their numbers in this assay, from the lowest: compounds 4 and 2 (each within the scatter of the next); then compound 3. At a limit, above all of these: compound 1.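

On a double-bonded chain carbon bound to a carbonyl carbon, trifluoromethyl in place of hydroxymethyl gives an at least 34-fold lower number from compound 1 to compound 4 (1.53 log units; beyond the scatter). The earlier step placed trifluoromethyl only on a double-bonded chain carbon bound to a double-bonded chain carbon, so the same association with the lower number now appears at this second place. The step is only a minimum because compound 1 stands at an assay limit: the limit of > 8.53 h in this assay, at which 1 of the 4 values shown sits.

The compounds shown do not separate the loss of hydroxymethyl from the entry of trifluoromethyl. On these data alone, what a methyl group, an amine or a carboxylic acid would give at this position remains open.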